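This account rests on a few compounds, and the source may have more. Where it says the series, first, only, none or still open, it means among the compounds named here.

Three compounds have been measured in an in vitro ADME assay on the whole organism (small intestine) for pharmacokinetics, with Rattus norvegicus as the target; on this read-out lower numbers stand for a shorter-lived compound and higher numbers for a longer-lived compound:

- Compound 1, `CCOC(=O)CN(C(=O)/C(C)=C/c1ccc(C(=O)Oc2ccc(C(=N)N)cc2)cc1)C1CCCCC1`, gives > 1 h, a limit of the assay rather than a number.
- Compound 2, `C/C(=C\c1ccc(C(=O)Oc2ccc(C(=N)N)cc2)cc1)C(=O)N(CC(=O)O)Cc1ccccc1`, gives 0.833 h.
- Compound 3, `CCOC(=O)CCCN(C(=O)/C(C)=C/c1ccc(C(=O)Oc2ccc(C(=N)N)cc2)cc1)C(C(=O)OCC)C(=O)OCC`, gives 1 h.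

All three share the same core and differ in the groups attached to the amide-type nitrogen. Compound 1 is known only from one side: it sits at the limit of > 1 h in this assay, at which 1 of the 3 values shown sits, so its exact half-life is not pinned down, and it cannot be ranked against compound 2 or compound 3 beyond what the limit itself shows.

The next compound, compound 4, `CCOC(=O)CN(C(=O)/C(C)=C/c1ccc(C(=O)Oc2ccc(C(=N)N)cc2)cc1)C1CCCC1`, is the closest relative of compound 1. The single difference is cyclopentyl in place of cyclohexyl on an amide-type nitrogen. For the measured compounds named here, no measured pair with a change of this kind is at hand, so the expectation rests on the small size of the change alone. The step expected a step that the limit leaves unreadable from compound 1 to compound 4 is none beyond the usual scatter of this assay. Compound 4 is therefore expected to give 1.2 h, with a range from 0.7 h to 2.5 h.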

Compound 4, half-life: > 1 h
Compound 4 was reported as a limit (the forecaster's own chance of this, stated with the estimate: 45%); the middle value is on the limit's open side.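

In this assay no step can be read from compound 1 to compound 4, because each is reported only as a limit: the limit of > 1 h in this assay, at which 2 of the 4 values shown sit.

The compounds shown leave open the actual half-lives of compound 1 and compound 4, and so whether cyclopentyl in place of cyclohexyl on an amide-type nitrogen changes the half-life at all.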